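This account rests on a few compounds, and the source may have more. Where it says the series, first, only, none or still open, it means among the compounds named here.

Working notes on the series. Compound 1 `CC1CCN(c2nc(Cl)nc3c2ncn3Cc2ccc(/C=C/C(=O)Nc3ccccc3N)cc2)CC1` gives 8.24% in a functional assay on NCI-H460 cells (Homo sapiens) for antiproliferative activity, read by CCK-8 assay, with a stated time of 72 h, tested at 2 uM; a higher number here means a stronger effect of the compound at the concentration tested, a lower number a weaker effect. Compound 2 `Nc1ccccc1NC(=O)/C=C/c1ccc(Cn2cnc3c(Nc4cccc(Cl)c4)nc(Cl)nc32)cc1` carries the change ((3-chlorophenyl)amino in place of 4-methylpiperidin-1-yl on an aromatic carbon), and in this assay compound 2 gives 7.11%; the step is a number 1.1 percentage points lower from compound 1 to compound 2 (within the scatter). Compound 3 `CC1CCN(c2nc(Cl)nc3c2ncn3Cc2ccc(C(=O)Nc3ccccc3N)cc2)CC1` differs from compound 1 by (2-aminophenyl)carbamoyl in place of 2-((2-aminophenyl)carbamoyl)ethenyl on an aromatic carbon; in this assay compound 3 gives 11.8%, the step being a number 3.6 percentage points higher from compound 1 to compound 3 (within the scatter). All three numbers sit within the scatter of one another, so no order among them is claimed.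

Compound 4 `Nc1ccccc1NC(=O)c1ccc(Cn2cnc3c(Nc4cccc(Cl)c4)nc(Cl)nc32)cc1` is not yet measured. It differs from compound 3 by (3-chlorophenyl)amino in place of 4-methylpiperidin-1-yl on an aromatic carbon, the same change as from compound 1 to compound 2, placed on the core of compound 3 rather than that of compound 1. Given that this change gave a number 1.1 percentage points lower from compound 1 to compound 2 (within the scatter), the step for compound 4 is expected to be similarly small, a number 1.1 percentage points lower from compound 3 to compound 4 (within the scatter). Compound 4 is estimated at 10.7% in this assay, with an expected range from 3% to 19%.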

Compound 4, a percentage reported as inhibition, at one concentration (the size of the read-out at that concentration, not a potency): 10.3%
Compound 4: the middle estimate sits 0.4 percentage points above what was measured; low and high end bracket the measured number.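

In this assay, (3-chlorophenyl)amino in place of 4-methylpiperidin-1-yl gives a number 1.5 percentage points lower from compound 3 to compound 4 (within the scatter), and the change reads alike on the two cores: the same change on two cores in this assay, a number 1.1 percentage points lower (within the scatter) from compound 1 to compound 2 and a number 1.5 percentage points lower (within the scatter) from compound 3 to compound 4, 0.4 percentage points apart, within the scatter of two such steps

(2-Aminophenyl)carbamoyl in place of 2-((2-aminophenyl)carbamoyl)ethenyl gives a number 3.2 percentage points higher from compound 2 to compound 4 (within the scatter), again alike on the two cores: the same change on two cores in this assay, a number 3.6 percentage points higher (within the scatter) from compound 1 to compound 3 and a number 3.2 percentage points higher (within the scatter) from compound 2 to compound 4, 0.4 percentage points apart, within the scatter of two such steps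

Neither change therefore shows a dependence on the core, but with every step within the scatter, this shows only that neither moves the read-out measurably on these two cores at this one concentration, not that an effect of a set size carries over, and it says nothing about potency.

Still open, as far as these compounds go, is whether a morpholine or a primary amine on that aromatic carbon, or a longer chain in place of the ethenyl, would give a step beyond the scatter.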